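Fluoro for chloro on the nitrogen-bound aryl ring

The source may hold more compounds than are shown below. What is called first, only, known or untested is meant among the compounds shown, and "the series" means these compounds.

The series rests on the shared core of compound 1 `O=C1COc2ccc(-c3cnc4ccccc4c3)cc2N1`. Compound 2 `O=C1COc2ccc(-c3cnc4ccccc4c3)cc2N1c1ccc(Cl)cc1` carries a 4-chlorophenyl on the amide-type nitrogen in the ring; compound 3 `COc1cccc(N2C(=O)COc3ccc(-c4ccc(O)cc4)cc32)c1` is a further member. In a functional assay on HeLa cells (Homo sapiens) for antiproliferative activity, read by MTT assay, with a stated time of 72 h (on this read-out higher numbers stand for weaker inhibition and lower numbers for stronger inhibition), compound 1 gives > 40000 nM, a limit of the assay and not a number. In this assay compound 2 gives > 40000 nM, again a limit. In this assay compound 3 gives > 40000 nM, also a limit. Compound 2 thus stands at the limit of > 40000 nM in this assay, at which 3 of the 3 values shown sit. The step that the two limits leave unreadable from compound 1 to compound 2 has no readable size. Compound 4 `O=C1COc2ccc(-c3cnc4ccccc4c3)cc2N1c1ccc(F)cc1` differs from compound 2 by fluoro in place of chloro on an aromatic carbon. For the measured compounds named here, no measured step speaks to this change. Compound 4 is therefore expected to give 50000 nM, from 15000 nM to 150000 nM, most likely reported only as a limit. The step that the limit leaves unreadable from compound 2 to compound 4 is estimated to lie within the scatter.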

Compound 4, half-maximal inhibitory concentration: 38800 nM
The estimate for compound 4 lay 1.3-fold (0.11 log units) above the measured number; the measured number falls inside the stated range.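

In this assay, fluoro in place of chloro on an aromatic carbon, para to a large group, gives an at least 1.0-fold lower number from compound 2 to compound 4 (0.01 log units; that floor lies within the scatter), and 4-fluorophenyl in place of hydrogen on the amide-type nitrogen gives an at least 1.0-fold lower number from compound 1 to compound 4 (0.01 log units; that floor lies within the scatter). Neither floor shows a change beyond the scatter, so this swap on the nitrogen-bound aryl ring gives no demonstrated gain. Compound 4 alone gives a number, and the rest of the set stays at a limit: the limit of > 40000 nM in this assay, at which 3 of the 4 values shown sit.

From the compounds shown here alone, the full size of both steps remains open. Also open, going by these compounds, is how an amine or a carboxylic acid in place of the fluoro would read in this assay.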